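The compounds below may be only part of what the source reports. "The series", "measured", "known", "first", "only" and "open" are said of these compounds alone.

Measured so far in a functional assay on B16 cells (Mus musculus) for inhibition, read by MTT assay, with a stated time of 24 h; a higher number here means a weaker inhibitor, a lower number a stronger inhibitor:
compound 1 `FC(F)(F)c1cc(NC[C@H]2CCCN2)c2cn[nH]c2c1`: > 20000 nM
compound 2 `O=[N+]([O-])c1cccc(CNc2cc(Br)cc3[nH]ncc23)c1`: > 20000 nM
compound 3 `COc1cc(CNc2cc(Br)cc3[nH]ncc23)c([N+](=O)[O-])cc1OC`: > 20000 nM

Compound 1 gives no number, since > 20000 nM is a limit of the assay. The same holds across the set: the limit of > 20000 nM in this assay, at which 3 of the 3 values shown sit.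

Next comes compound 4 `FC(F)(F)c1cc(NC[C@@H]2CCCCN2)c2cn[nH]c2c1`, with piperidin-2-yl in place of pyrrolidin-2-yl on a saturated chain carbon bound to a nitrogen on an aromatic ring. Within the data shown here, no measured pair shows what this change does in this assay, so no step beyond the scatter is expected, in either direction. The expectation rests on compound 1 at > 20000 nM, again a limit. The expected change is a number no higher from compound 1 to compound 4 (the limit leaves the size open). A further limit is the likeliest report. The estimate for compound 4 is 20000 nM, with an expected range of 8000 nM to 40000 nM.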

Compound 4, half-maximal inhibitory concentration: > 20000 nM
Compound 4: no number, only a limit; the forecaster's own chance of this, stated with the estimate: 75%; the middle value lies on the limit itself.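

Compound 1 and compound 4 each give only a limit, so no step can be read between them: the limit of > 20000 nM in this assay, at which 4 of the 4 values shown sit. The compounds shown leave open whether piperidin-2-yl in place of pyrrolidin-2-yl changes inhibition in this assay at all.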